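A few compounds are considered here, and "the series" means these few. Any claim that something is new, unique, unknown or untested is made for them only; others in the source may bear on it.

Three amides built on one shared core have been examined in a toxicity assay on THP-1 cells (Homo sapiens) for inhibition; a lower number here means that less compound is tolerated, a higher number that more compound is tolerated. Compound 1 `COc1ccc(-c2cnc(NC(=O)c3ccc(Br)cc3)n2C)cc1` carries a 4-bromophenyl group on the carbonyl carbon. In this assay compound 1 reaches only the limit of the measurement, > 100000 nM. Compound 2 `COc1ccc(-c2cnc(NC(=O)c3cccc(F)c3)n2C)cc1` carries a 3-fluorophenyl group at the same place. In this assay compound 2 likewise reaches only the limit, > 100000 nM. Compound 3 `COc1ccc(-c2cnc(NC(=O)c3ccccc3Br)n2C)cc1` carries a 2-bromophenyl group there. In this assay compound 3 also gives only the limit, > 100000 nM. Compound 3 thus stands at a limit rather than at a number, and the two other values shown stand at the same limit, so no order among the three can be read. The steps a step that the two limits leave unreadable from compound 1 to compound 2, a step that the two limits leave unreadable from compound 1 to compound 3 and a step that the two limits leave unreadable from compound 2 to compound 3 have no readable size. The step to compound 4 `COc1ccc(-c2cnc(NC(=O)c3ccc(Cl)cc3)n2C)cc1` is 4-chlorophenyl in place of 2-bromophenyl on a carbonyl carbon. All three measured steps, each a swap of one substituted phenyl ring for another on the same carbonyl carbon, bear on it, and each was left unreadable because of the limit of > 100000 nM in this assay, at which 3 of the 3 values shown sit. No direction and no size beyond the scatter can therefore be expected in this assay. Compound 4 is expected to sit at the limit as well, with the expected step of a number no higher from compound 3 to compound 4 (the limit leaves the size open). The estimate for compound 4 is 100000 nM, within 50000 nM to 300000 nM.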

Compound 4, half-maximal cytotoxic concentration: > 100000 nM
Compound 4: only a limit was reported; the forecaster's own chance of this, stated with the estimate: 85%; the middle value sits exactly at the limit.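

In this assay compound 4 gives > 100000 nM, a limit and not a number. Its steps to compound 1, compound 2 and compound 3 therefore cannot be read, because the values give no number to compare: the limit of > 100000 nM in this assay, at which 4 of the 4 values shown sit.

The compounds shown leave open whether the four amides differ at all in this assay, and at what concentration any of them would reach the half-maximal cytotoxic effect.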